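This account rests on a few compounds, and the source may have more. Where it says the series, first, only, none or still open, it means among the compounds named here.

Of the compounds shown here, two that share one core have been measured in a functional assay on HeLa cells (Homo sapiens) for antiproliferative activity, with a stated time of 24 h; a lower number here means a stronger inhibitor, a higher number a weaker inhibitor. Compound 1 `NC(=O)c1c(NC(=O)c2ccccc2Cl)sc2c1CCN(Cc1ccccc1Cl)C2` gives 27500 nM. Compound 2 `NC(=O)c1c(NC(=O)c2ccccc2Cl)sc2c1CCN(C(=S)Nc1ccccc1F)C2` gives 28700 nM, the higher of the two numbers, though the step of a 1.0-fold higher number from compound 1 to compound 2 (0.02 log units; within the scatter) lies within the scatter, so the two are not separable. Compound 3 `CSc1ccccc1NC(=S)N1CCc2c(sc(NC(=O)c3ccccc3Cl)c2C(N)=O)C1` has not been measured. It differs from compound 2 by methylsulfanyl in place of fluoro on an aromatic carbon. For the measured compounds named here, the only measured step, a 1.0-fold higher number from compound 1 to compound 2 (0.02 log units; within the scatter), exchanged a whole side group on the amine nitrogen in a ring without moving the number; no measured step alters a group on the six-membered aromatic ring of carbon only itself, so the data give no direct guide to this kind of change. On this basis no shift beyond the scatter is expected, and compound 3 is estimated at 28000 nM, within 10000 nM to 80000 nM. The expected step is a 1.0-fold lower number from compound 2 to compound 3 (0.01 log units; within the scatter).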

Compound 3, half-maximal inhibitory concentration: 43600 nM
Compound 3: the middle estimate sits 1.6-fold (0.19 log units) below what was measured, within the range that was stated.
By their numbers in this assay, from the lowest: compounds 1, 2 and 3 (each within the scatter of the next).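

In this assay, for the compounds shown here, methylsulfanyl in place of fluoro on an aromatic carbon, ortho to a large group, gives a 1.5-fold higher number from compound 2 to compound 3 (0.18 log units; within the scatter) and is the first measured change on the six-membered aromatic ring of carbon only itself, so going from 2-fluorophenyl to 2-(methylsulfanyl)phenyl does not separate the two compounds. The wider exchange of the side group on the amine nitrogen in a ring, a 1.6-fold higher number from compound 1 to compound 3 (0.20 log units; within the scatter) in this assay, likewise leaves the compounds inseparable, so none of the three side groups stands apart from the others. No supporting evidence bears on this result.

From the compounds shown here alone, whether an amine or a carboxylic acid on the same aromatic carbon would move the number beyond the scatter remains open. So does whether any change to the shared core itself would do so, as every step shown lies within the scatter.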